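The source may report more compounds than this note shows. Statements on the series, on what has been measured and on what is new or still open speak of the compounds shown alone.

Working notes on the series. Within the data shown here, in a functional assay on isolated protein for inhibition of Glucose-dependent insulinotropic receptor (Rattus norvegicus), read by HTRF and cAMP accumulation (a lower number here means that less compound is needed, a higher number that more compound is needed for the effect), compound 2 `Cc1nc(S(C)(=O)=O)ccc1Oc1ncnc(OC2CCN(C(=O)OC3(C(F)(F)F)COC3)CC2)c1F` gives 342 nM, the higher of the two numbers measured so far. Its nearest neighbour is compound 1 `Cc1nc(S(C)(=O)=O)ccc1Oc1ncnc(OC2CCN(C(=O)OC3CCC3)CC2)c1F`, which in this assay gives 167 nM. Among the measured compounds shown here, the only measured step, a 2.0-fold higher number from compound 1 to compound 2 (0.31 log units; beyond the scatter), concerns the group on the oxygen of the carbamate and does not touch the kind of change made here. For the measured compounds named here, compound 3 `Cc1nc(S(C)(=O)=O)ccc1Oc1ncnc(OC2CCN(C(=O)C3(F)CCC3)CC2)c1F` differs from compound 2 as follows: a group of 5 heavy atoms (4 carbon, 1 fluorine; one four-membered non-aromatic ring of carbon only) in place of a group of 9 heavy atoms (4 carbon, 2 oxygen, 3 fluorine; one four-membered non-aromatic ring with 1 hetero atom), on a carbonyl carbon No measured pair in this set exchanges an oxygen-linked group for a carbon ring on the carbonyl carbon, so the direction of the step cannot be read from compound 1. Since both measured values lie close together, compound 3 is expected near them, with an estimate of 260 nM and a range from 100 nM to 700 nM. The expected step from compound 2 is a 1.3-fold lower number from compound 2 to compound 3 (0.12 log units; within the scatter), within the scatter.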

Compound 3, half-maximal effective concentration: 123 nM
The estimate for compound 3 lay 2.1-fold (0.33 log units) above the measured number, and the stated range covers the measured number.
By their numbers in this assay, from the lowest: compounds 3 and 1 (each within the scatter of the next); then compound 2.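

In this assay, the fluorine-bearing four-membered carbon ring on the carbonyl carbon, in place of the (3-(trifluoromethyl)oxetan-3-yl)oxy group, gives a 2.8-fold lower number from compound 2 to compound 3 (0.44 log units; beyond the scatter), so this position accepts a group with no oxygen link and the number does not rise. Set against the cyclobutyl carbamate, the same ring gives a 1.4-fold lower number from compound 1 to compound 3 (0.13 log units; within the scatter), which is within the scatter, so these two groups on the carbonyl carbon cannot be told apart in this assay. Nothing available explains either step.

The compounds shown leave open what the fluorine on the carbon ring contributes, since no plain cyclobutyl group sits directly on the carbonyl carbon here. Also open, going by these compounds, is whether an amine or a longer chain at this carbonyl carbon would give a number in the same range.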